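The compounds below may be only part of what the source reports. "The series", "measured", "known", "first", "only" and "open" are said of these compounds alone.

Measured:
Compound 1 `CCc1nnc(SC)n1N1C(=O)c2ccccc2C1=O` in a functional assay on A549 cells (Homo sapiens) for cytotoxicity, read by MTT assay, with a stated time of 48 h; on this read-out lower numbers stand for stronger inhibition and higher numbers for weaker inhibition: > 200000 nM, a limit only.
Compound 2 `C#CCSc1nnc(-c2cc(OC)c(OC)c(OC)c2)n1N1C(=O)c2ccccc2C1=O` in this assay: > 200000 nM, a limit only.

Compound 2 stands at the limit of this assay, and compound 1 sits there too (the limit of > 200000 nM in this assay, at which 2 of the 2 values shown sit). Among the compounds with values here, no step between measured compounds is available, so no measured change gives a direction. Compound 3 `COc1cc(-c2nnc(SCC(=O)c3ccc(F)c(F)c3)n2N2C(=O)c3ccccc3C2=O)cc(OC)c1OC` differs from compound 2 by (3,4-difluorophenyl)carbonyl in place of ethynyl on a saturated chain carbon bound to a sulfur. With both known values at the limit, compound 3 is expected to remain near it, the expected step being an at least 1.3-fold lower number from compound 2 to compound 3 (0.12 log units; that floor lies within the scatter) and not clearly beyond the scatter. The estimate for compound 3 is 150000 nM, ranging from 30000 nM to 300000 nM.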

Compound 3, half-maximal inhibitory concentration: > 200000 nM
Compound 3 gave a limit, no number; the forecaster's own chance of this, stated with the estimate: 60%; at least 1.3-fold (0.12 log units) between middle value and limit.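

No step can be read from compound 2 to compound 3 in this assay, since both values are limits: the limit of > 200000 nM in this assay, at which 3 of the 3 values shown sit.

The compounds shown leave open whether any group on the saturated chain carbon bound to a sulfur gives a readable number in this assay.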